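From thiophen-3-yl to pyridin-4-yl on the shared core

This account rests on a few compounds, and the source may have more. Where it says the series, first, only, none or still open, it means among the compounds named here.

Values measured in a functional assay on THP-1 cells (Homo sapiens) for inhibition, read by ELISA, with stated times of 1 h and 18 h (a lower number here means a stronger inhibitor, a higher number a weaker inhibitor), are as follows.
Compound 1 `NC(=O)[C@@H]1[C@H](Nc2nc(Nc3cccc(C(=O)N4CCCC4)c3)ncc2C2CC2)[C@H]2C=C[C@@H]1C2` gives 90 nM here
Compound 2 `NC(=O)[C@@H]1[C@H](Nc2nc(Nc3cccc(C(=O)N4CCCC4)c3)ncc2-c2ccoc2)[C@H]2C=C[C@@H]1C2` gives 40 nM here
Compound 3 `NC(=O)[C@@H]1[C@H](Nc2nc(Nc3cccc(C(=O)N4CCCC4)c3)ncc2-c2ccsc2)[C@H]2C=C[C@@H]1C2` gives 110 nM here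

In this assay compound 3 stands at 110 nM and is not set apart from the cyclopropyl analogue, the data showing a 1.2-fold higher number from compound 1 to compound 3 (0.09 log units; within the scatter) for that swap. The furan-3-yl analogue does differ from it, with a 2.8-fold higher number from compound 2 to compound 3 (0.44 log units; beyond the scatter) as the gap.

Compound 4 `NC(=O)[C@@H]1[C@H](Nc2nc(Nc3cccc(C(=O)N4CCCC4)c3)ncc2-c2ccncc2)[C@H]2C=C[C@@H]1C2` changes the same place on the core, and the difference is counted as follows: pyridin-4-yl in place of thiophen-3-yl on an aromatic carbon in all. In words, this is pyridin-4-yl in place of thiophen-3-yl on an aromatic carbon. The three measured steps all concern this place. Besides the two above, there is a 2.3-fold lower number from compound 1 to compound 2 (0.35 log units; beyond the scatter) for the swap to furan-3-yl, so no swap here has moved the number by more than a modest amount. Among the measured compounds shown here, none of the measured compounds carries a six-membered aromatic ring at this place, so the data give no direct guide to direction.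

The expected step is therefore small, a 1.1-fold lower number from compound 3 to compound 4 (0.04 log units; within the scatter) as estimated, and none beyond the scatter is expected. For compound 4 the estimated value is 100 nM in a range from 35 nM to 280 nM as expected limits.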

Compound 4, half-maximal inhibitory concentration: 320 nM
Beside the measured number, compound 4's estimate is 3.2-fold (0.51 log units) below it; the whole stated range lies below it.
By their numbers in this assay, from the lowest: compound 2; then compounds 1 and 3 (each within the scatter of the next); then compound 4.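

In this assay, pyridin-4-yl, the only six-membered aromatic ring among these compounds at this place, gives a 2.9-fold higher number from compound 3 to compound 4 (0.46 log units; beyond the scatter), showing that this position on the shared core does not accept every aromatic group equally. The group also stands apart from the other two, with a 3.6-fold higher number from compound 1 to compound 4 (0.55 log units; beyond the scatter) and an 8.0-fold higher number from compound 2 to compound 4 (0.90 log units; beyond the scatter), the second being the widest gap seen at this place and making compound 4 the weakest inhibitor of the four. Thiophen-3-yl and pyridin-4-yl carry the same counts of hydrogen-bond donors and acceptors and no net charge, so those counts do not separate compound 3 from compound 4, although the two groups differ in ring size and in their hetero atom.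

Nothing available here accounts for the higher number of compound 4. The compounds shown also cannot separate ring size from the ring nitrogen, and it remains open whether phenyl or pyridin-3-yl at this place would fall nearer to compound 3 or to compound 4.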